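This account rests on a few compounds, and the source may have more. Where it says the series, first, only, none or still open, it means among the compounds named here.

Compound 1 `CCCCCc1ccc(-c2cn(C[C@H](O)[C@H]3OC(=O)C(OCc4ccccc4)=C3OCc3ccccc3)nn2)cc1` is the reference point in a functional assay on CFPAC-1 cells (Homo sapiens) for antiproliferative activity, read by MTT assay, with a stated time of 72 h (a lower number here means a stronger inhibitor, a higher number a weaker inhibitor), where compound 1 gives 9890 nM, the only plain number shown. Compound 2 `O=C1O/C(=C\Cn2cc(-c3cc(C(F)(F)F)cc(C(F)(F)F)c3)nn2)C(OCc2ccccc2)=C1OCc1ccccc1` returns only a limit of the assay, > 100000 nM, which is the limit of > 100000 nM in this assay, at which 1 of the 2 values shown sits. Compound 3 `O=C1O[C@H]([C@@H](O)Cn2cc(-c3cc(F)cc(F)c3)nn2)C(OCc2ccccc2)=C1OCc1ccccc1` differs from compound 1 by 3,5-difluorophenyl in place of 4-pentylphenyl on an aromatic carbon. Among the measured compounds shown here, no measured pair shows the effect of such a change, so the size of the step is uncertain; a loss of potency beyond the usual scatter is expected, and the expected step is a 3.0-fold higher number from compound 1 to compound 3 (0.48 log units; beyond the scatter). Compound 3 is therefore expected to give about 30000 nM in this assay, between 8000 nM and 100000 nM.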

Compound 3, half-maximal inhibitory concentration: 62400 nM
The estimate for compound 3 lay 2.1-fold (0.32 log units) below the measured number, and the stated range covers the measured number.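

Placing 3,5-difluorophenyl in place of 4-pentylphenyl on this aromatic carbon gives a 6.3-fold higher number from compound 1 to compound 3 (0.80 log units; beyond the scatter) in this assay, the only measured step at this position. The swap removes the pentyl chain and adds two fluorines at once, so this step cannot show which of the two changes matters. Compound 2 offers no number for comparison, only a limit: the limit of > 100000 nM in this assay, at which 1 of the 3 values shown sits.

Still open, from the compounds shown here alone, is whether the pentyl chain itself matters. A plain phenyl, a 4-fluorophenyl or a longer chain such as octyl at this position could separate the two changes.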